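From compound 3 to compound 4: a sparse starting point

A few compounds are considered here, and "the series" means these few. Any claim that something is new, unique, unknown or untested is made for them only; others in the source may bear on it.

Measured compounds:
compound 1 `COc1cc(/C=C/c2cc(/C=C/c3ccc(O)c(OC)c3)n(C(N)=O)n2)ccc1O`: "not determined" (no result reported)
compound 2 `COc1cc(/C=C/c2cc(/C=C/c3ccc(O)c(OC)c3)n(C(=O)c3ccncc3)n2)ccc1O`: > 100000000 nM
compound 3 `COc1cc(/C=C/C(=O)C(=Cc2ccccc2)C(=O)/C=C/c2ccc(O)c(OC)c2)ccc1O`: "not determined" (no result reported)

The data set in an ADME assay on L123 cells (Homo sapiens) for cytotoxicity, read by MTT assay, with a stated time of 48 h (on this read-out higher numbers stand for weaker inhibition and lower numbers for stronger inhibition), is very thin. Compound 2 gives > 100000000 nM in this assay, and this is a limit of the assay, not a number. Compound 1 shows "not determined" (no result reported) in the same test, so it adds no figure either. Compound 3 stands without a number of its own, with the entry "not determined" (no result reported), and so offers no fixed point from which to measure.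

The next compound is compound 4 `COc1cc(/C=C/C(=O)C(=Cc2ccc(N(C)C)cc2)C(=O)/C=C/c2ccc(O)c(OC)c2)ccc1O`, which has yet to be tested in this assay. The structural change is a single one: dimethylamino in place of hydrogen on an aromatic carbon. In words, dimethylamino takes the place of hydrogen on an aromatic carbon, para to a large group, turning phenyl into 4-(dimethylamino)phenyl.

Going by the values given here, no pair of measured compounds in this assay shows what a single change of this kind does. The expectation for this change is therefore no step beyond the scatter, with neither direction favoured. The test may also return only a limit for the new compound, and the range has to stay wide. For compound 4 the value is estimated at 5000000 nM, with an expected range from 20000 nM to 100000000 nM.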

Compound 4, half-maximal inhibitory concentration: > 100000000 nM
Compound 4: a limit, no number; the forecaster's own chance of this, stated with the estimate: 50%; at least 20-fold (1.30 log units) between middle value and limit.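

In this assay compound 4 gives > 100000000 nM, which is a limit of the assay and not a number. Going by these compounds alone, compound 3 stands at "not determined" (no result reported), so no step from compound 3 to compound 4 can be read. The compounds shown leave open what dimethylamino in place of hydrogen does to the value, and where any of these compounds would give a number: the limit of > 100000000 nM in this assay, at which 2 of the 4 values shown sit.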